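Three limits on one core, a fourth substituent to come

The source may report more compounds than this note shows. Statements on the series, on what has been measured and on what is new or still open speak of the compounds shown alone.

Compound 3 `COc1ccc(Nc2ncc(C)c(Nc3nc4ccccc4s3)n2)cc1` in a functional assay on MDA-MB-231 cells (Homo sapiens) for antiproliferative activity, read by MTT assay, with a stated time of 48 h (on this read-out higher numbers stand for weaker inhibition and lower numbers for stronger inhibition), gives only a limit, > 50000 nM. Compound 1 `Cc1cnc(Nc2ccc(C(C)C)cc2)nc1Nc1nc2ccccc2s1` in this assay likewise gives only a limit, > 50000 nM. Compound 2 `Cc1cnc(Nc2ccc(Cl)cc2)nc1Nc1nc2ccccc2s1` in this assay also gives only a limit, > 50000 nM. The three steps among them, a step that the two limits leave unreadable from compound 1 to compound 2, a step that the two limits leave unreadable from compound 1 to compound 3 and a step that the two limits leave unreadable from compound 2 to compound 3, are therefore without readable size; all three values sit at the limit of > 50000 nM in this assay, at which 3 of the 3 values shown sit. Compound 3 thus stands at the same limit as the other two, with no number to rank it by.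

Compound 4 `Cc1cnc(Nc2ccc(N3CCCCC3)cc2)nc1Nc1nc2ccccc2s1` differs from compound 3 by piperidin-1-yl in place of methoxy on an aromatic carbon. The measured steps that bear on this change are the three exchanges on an aromatic carbon of the shared core, each running from limit to limit, so they give neither a direction nor a size to carry over. On that basis the step from compound 3 to compound 4 in this assay is expected to be a step that the limit leaves unreadable from compound 3 to compound 4, most likely ending again at a limit. Compound 4 is estimated at 60000 nM, within 15000 nM to 200000 nM.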

Compound 4, half-maximal inhibitory concentration: 37200 nM
For compound 4 the middle estimate is 1.6-fold (0.21 log units) above the measured one; low and high end bracket the measured number.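

Going by these compounds alone, on an aromatic carbon para to a large group, piperidin-1-yl is the first substituent on the shared core to give a number rather than a limit in this assay, so changes at this place now have a measured end point: the limit of > 50000 nM in this assay, at which 3 of the 4 values shown sit.
The exchange reads as an at least 1.3-fold lower number from compound 3 to compound 4 (0.12 log units; that floor lies within the scatter) and, from the other two groups, as an at least 1.3-fold lower number from compound 2 to compound 4 (0.12 log units; that floor lies within the scatter) and as an at least 1.3-fold lower number from compound 1 to compound 4 (0.12 log units; that floor lies within the scatter) on the same read-out.
From the compounds shown here alone, each of these is only a floor set by a limit, so the true size remains unknown, and the steps among compounds 1, 2 and 3 cannot be read.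

Open, going by these compounds, is whether the six-membered ring or its nitrogen matters here, which morpholin-4-yl or a dimethylamino group at this place would help separate.
Also open, on these data alone, is how a carboxylic acid or a longer chain would read at this place.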